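The source may hold more compounds than are shown below. What is called first, only, known or untested is meant among the compounds shown, and "the series" means these compounds.

In an assay for inhibition of histone-lysine N-methyltransferase EZH2 variant Y641N (Homo sapiens), read by scintillation counting, with a stated time of 60 min, in the presence of a further agent that is not named here (on this read-out lower numbers stand for stronger inhibition and higher numbers for weaker inhibition), the measured compounds are:

Compound 1 `Cc1cc(C)c(CN2CCc3c(Cl)cc([C@@H](CO)[C@@H]4CCCO4)c(Cl)c3C2=O)c(=O)[nH]1`: 135 nM
Compound 2 `Cc1cc(C)c(CN2CCc3c(Cl)cc(-c4c(C)noc4C)c(Cl)c3C2=O)c(=O)[nH]1`: 1.15 nM
Compound 3 `COC(C)c1cc(Cl)c2c(c1Cl)C(=O)N(Cc1c(C)cc(C)[nH]c1=O)CC2`: 49 nM; 34 nM (2 entries)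

Compound 2 stands lowest of the two single numbers, and its nearest neighbour, compound 1, is separated from it by a large step, a 120-fold lower number from compound 1 to compound 2 (2.07 log units; beyond the scatter). Compound 3 contributes repeated entries, (the several entries of compound 3 in this assay, 49 nM; 34 nM (2 entries)), which agree with each other within the usual scatter.

Compound 4 `Cc1cc(C)c(CN2CCc3c(Cl)cc([C@@H](CO)[C@H]4CCCO4)c(Cl)c3C2=O)c(=O)[nH]1` differs from compound 2 by a group of 8 heavy atoms (6 carbon, 2 oxygen; one five-membered non-aromatic ring with 1 hetero atom) in place of a group of 7 heavy atoms (5 carbon, 1 nitrogen, 1 oxygen; one five-membered aromatic ring with 2 hetero atoms), on an aromatic carbon, the position being ortho to a chloro group and meta to a fused ring. The group that enters carries two defined stereocentres, and compound 4 differs from compound 1 only in one of them; otherwise the change simply reverses the step from compound 1 to compound 2. Within the data shown here, the one measured step that bears on it was large, so compound 4 is expected to give a large step upward, a 130-fold higher number from compound 2 to compound 4 (2.12 log units; beyond the scatter). The estimate for compound 4 is 150 nM, with a range from 40 nM to 600 nM.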

Compound 4, inhibition constant: 110 nM
Compound 4: the middle estimate sits 1.4-fold (0.13 log units) above what was measured, and the stated range covers the measured number.
By their numbers in this assay, from the lowest: compound 2; then compounds 4 and 1 (each within the scatter of the next).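

The large step seen earlier recurs with the other drawn configuration: at this aromatic carbon, ortho to a chloro group, putting the group with one five-membered non-aromatic ring in place of 3,5-dimethyl-1,2-oxazol-4-yl gives a 96-fold higher number from compound 2 to compound 4 (1.98 log units; beyond the scatter). The drawn configuration at the saturated ring carbon separates nothing here, with a 1.2-fold lower number from compound 1 to compound 4 (0.09 log units; within the scatter). The gap to compound 2 therefore does not rest on that one stereocentre, a reading that holds for a single pair: the fact that compounds 1 and 4 differ only in the configuration as drawn

The compounds shown leave open whether the other stereocentre, which compound 1 and compound 4 share, matters, and which part of the entering group goes with the gap to compound 2. They also leave open how an amine or a carboxylic acid on this aromatic carbon would compare with the 3,5-dimethyl-1,2-oxazol-4-yl group of compound 2.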